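Furan-2-yl in place of phenyl on compound 3

The source may report more compounds than this note shows. Statements on the series, on what has been measured and on what is new or still open speak of the compounds shown alone.

In a functional assay on HCT-116 cells (Homo sapiens) for inhibition, with a stated time of 72 h (on this read-out higher numbers stand for weaker inhibition and lower numbers for stronger inhibition), compound 1 `NC1CCC(Nc2nc(NCc3ccc(-c4ccco4)cc3)c3ncn(C4CCCC4)c3n2)CC1` gives 129 nM, compound 2 `NC1CCC(Nc2nc(NCc3ccc(-n4cccn4)cc3)c3ncn(C4CCCC4)c3n2)CC1` gives 320 nM and compound 3 `NC1CCC(Nc2nc(NCc3ccc(-c4ccccc4)nc3)c3ncn(C4CCCC4)c3n2)CC1` gives 563 nM. The position of compound 3 among the three is set by a 1.8-fold higher number from compound 2 to compound 3 (0.25 log units; within the scatter), and by a 4.4-fold higher number from compound 1 to compound 3 (0.64 log units; beyond the scatter). Compound 4 `NC1CCC(Nc2nc(NCc3ccc(-c4ccco4)nc3)c3ncn(C4CCCC4)c3n2)CC1` has furan-2-yl in place of phenyl on an aromatic carbon. The closest evidence is a 4.4-fold higher number from compound 1 to compound 3 (0.64 log units; beyond the scatter), where 6-phenylpyridin-3-yl replaces 4-(furan-2-yl)phenyl, so the loss of furan-2-yl comes together with a second change. Losing furan-2-yl also accompanies a 2.5-fold higher number from compound 1 to compound 2 (0.39 log units; beyond the scatter). A modest fall in the number is therefore expected, recovering part of the first of these steps. The estimated change is a 2.2-fold lower number from compound 3 to compound 4 (0.34 log units; beyond the scatter). For compound 4 the expected value is 260 nM, with an estimated range of 110 nM to 600 nM.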

Compound 4, half-maximal inhibitory concentration: 86 nM
Beside the measured number, compound 4's estimate is 3.0-fold (0.48 log units) above it; the measured number lies below the stated range.
By their numbers in this assay, from the lowest: compounds 4 and 1 (each within the scatter of the next); then compounds 2 and 3 (each within the scatter of the next).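

For the compounds shown here, on the aromatic carbon next to the ring nitrogen, furan-2-yl in place of phenyl gives a 6.5-fold lower number from compound 3 to compound 4 (0.82 log units; beyond the scatter) in this assay, the first step here that changes only this end group on the six-membered aromatic ring with 1 nitrogen. Against the 4-(1H-pyrazol-1-yl)phenyl group, 6-(furan-2-yl)pyridin-3-yl gives a 3.7-fold lower number from compound 2 to compound 4 (0.57 log units; beyond the scatter), whereas against 4-(furan-2-yl)phenyl it gives a 1.5-fold lower number from compound 1 to compound 4 (0.18 log units; within the scatter), so these two furan-bearing groups cannot be separated in this assay. No measurement at hand accounts for the gain from furan-2-yl.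

Still open, as far as these compounds go, is how thiophen-2-yl or a carboxylic acid at the same carbon would compare with furan-2-yl.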